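Ester tail variation and rat microsomal half-life

This account rests on a few compounds, and the source may have more. Where it says the series, first, only, none or still open, it means among the compounds named here.

Compound 1 `CCOC(=O)/C=C/c1ccc(NC(=O)C2(NC(=O)c3ccc4c(C5CCCC5)c(-c5ncc(Cl)cn5)n(C)c4c3)CCC2)cc1OCC`, compound 2 `CCOc1cc(NC(=O)C2(NC(=O)c3ccc4c(C5CCCC5)c(-c5ncc(Cl)cn5)n(C)c4c3)CCC2)ccc1/C=C/C(=O)OCC(C)C` and compound 3 `CCOc1cc(NC(=O)C2(NC(=O)c3ccc4c(C5CCCC5)c(-c5ncc(Cl)cn5)n(C)c4c3)CCC2)ccc1/C=C/C(=O)OCC(=O)OC` share one core and differ only in the ester tail. In an ADME assay (liver) for pharmacokinetics, with Liver microsome (Rattus norvegicus) as the target, using microsomes (a lower number here means that the compound disappears faster, a higher number that the compound lasts longer), compound 1 gives 3.07 h, compound 2 gives 1.42 h and compound 3 gives 2.08 h. On the bare numbers compound 3 stands second highest of the three, but both of its gaps lie within the scatter: a 1.5-fold lower number from compound 1 to compound 3 (0.17 log units; within the scatter) and a 1.5-fold higher number from compound 2 to compound 3 (0.17 log units; within the scatter). Among the measured compounds shown here, the only step beyond the scatter is a 2.2-fold lower number from compound 1 to compound 2 (0.33 log units; beyond the scatter), a modest one. Compound 4 `CCOc1cc(NC(=O)C2(NC(=O)c3ccc4c(C5CCCC5)c(-c5ncc(Cl)cn5)n(C)c4c3)CCC2)ccc1/C=C/C(=O)OCC(N)=O` has not been measured. Its change from compound 3 is amino in place of methoxy on a carbonyl carbon. For the measured compounds named here, none of the measured steps touches a carbonyl carbon of this kind; all three swap groups on the saturated chain carbon bound to an oxygen next to a carbonyl group, and two of them stayed within the scatter. The step expected in this assay for compound 4 is therefore a 1.0-fold lower number from compound 3 to compound 4 (0.02 log units; within the scatter), none beyond the scatter. Compound 4 is estimated at 2 h, with a range from 1 h to 4 h.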

Compound 4, half-life: 0.383 h
Compound 4: the middle estimate sits 5.2-fold (0.72 log units) above what was measured; measured number outside the range, below it.
By their numbers in this assay, from the lowest: compound 4; then compounds 2, 3 and 1 (each within the scatter of the next, the first and the last beyond it).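

Amino in place of methoxy on a carbonyl carbon gives, in this assay, a 5.4-fold lower number from compound 3 to compound 4 (0.73 log units; beyond the scatter), so a change at this carbonyl carbon, which the earlier steps left untouched, can shift the half-life further than any swap among the three esters did. The carbamoyl tail also stands apart from the other two tails, with a 3.7-fold lower number from compound 2 to compound 4 (0.57 log units; beyond the scatter) and an 8.0-fold lower number from compound 1 to compound 4 (0.90 log units; beyond the scatter), which leaves compound 4 with the shortest half-life of the four. Nothing measured here bears on the origin of this shift.

Still open, on these data alone, is whether the shift follows the amino group itself or the loss of methoxy. A methylamino or dimethylamino group, or a carboxylic acid, on the same carbonyl carbon would separate these readings, and the compounds shown do not settle which tail such a group would resemble.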